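The compounds below may be only part of what the source reports. "The series", "measured", "known", "first", "only" and "open" are said of these compounds alone.

Compound 2 `COC(=O)CC(=O)N1N=C(c2ccc(-n3ccnc3)cc2)CC1c1ccc(N(C)C)cc1` and compound 1 `CN(C)c1ccc(C2CC(c3ccc(-n4ccnc4)cc3)=NN2C(=O)CCCl)cc1` share one core and differ only in the group on a chain carbon next to a carbonyl. In a functional assay on HCC1806 cells (Homo sapiens) for inhibition, read by sulforhodamine B assay, tested at 10 uM (on this read-out lower numbers stand for less inhibition and higher numbers for more inhibition at the one concentration tested (going by the name of the read-out)), compound 1 gives -5.2%, and compound 2 gives 2.1%; the two values lie within the usual scatter of each other, as the step of a number 7.3 percentage points higher from compound 1 to compound 2 (within the scatter) shows, so neither compound can be set above the other. Compound 3 `CN(C)c1ccc(C2CC(c3ccc(-n4ccnc4)cc3)=NN2C(=O)c2ccc(F)cc2)cc1` is the next compound, differing from compound 2 by 4-fluorophenyl in place of (methoxycarbonyl)methyl on a carbonyl carbon. Among the compounds with values here, no measured step matches this change: the only measured step swaps one small chain group for another at the same place and stays within the scatter, so there is nothing to say that a ring group on that carbonyl carbon would move the number. Compound 3 is therefore expected to stay near the values seen so far, with an estimate of 5% and a range from -12% to 22%, which means an expected step of a number 2.9 percentage points higher from compound 2 to compound 3 (within the scatter) that would remain within the scatter.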

Compound 3, a percentage reported as inhibition, at one concentration (the size of the read-out at that concentration, not a potency): 7.1%
Beside the measured number, compound 3's estimate is 2.1 percentage points below it; low and high end bracket the measured number.
By their numbers in this assay, from the lowest: compounds 1, 2 and 3 (each within the scatter of the next, the first and the last beyond it).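

Within the data shown here, with a ring now on the carbonyl carbon, the change from 2-chloroethyl to 4-fluorophenyl gives a number 12.3 percentage points higher from compound 1 to compound 3 (beyond the scatter), the first step in this assay to clear the scatter. Among these compounds, the change from (methoxycarbonyl)methyl to 4-fluorophenyl gives only a number 5 percentage points higher from compound 2 to compound 3 (within the scatter), so the two chain groups and the ring group are not cleanly separated, and the one larger step rests on a single pair. Compound 3 still reaches just 7.1% at the one concentration tested, and no outside measurement accounts for the step.

The compounds shown cannot tell whether the ring or its fluorine matters, which a plain phenyl group on the same carbon could test. Going by these compounds, how an amine, a carboxylic acid or a longer chain would read there also remains open.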